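Allyl in place of hydrogen: working notes on compound 4

The source may hold more compounds than are shown below. What is called first, only, known or untested is meant among the compounds shown, and "the series" means these compounds.

Compound 1 `c1ccn(Nc2ccncc2)c1` gives > 20 mg/kg in a functional assay on the whole organism with Mus musculus as the target (on this read-out lower numbers stand for an effect already at smaller amounts and higher numbers for an effect only at larger amounts of compound), which is a limit and not a number. Compound 2 `CCCCN(c1ccncc1)n1cccc1` gives > 20 mg/kg, again a limit. Compound 3 `c1ccc(CN(c2ccncc2)n2cccc2)cc1` gives > 20 mg/kg, also a limit. The evidence so far is the limit of > 20 mg/kg in this assay, at which 3 of the 3 values shown sit.

Compound 4 `C=CCN(c1ccncc1)n1cccc1` differs from compound 1 by allyl in place of hydrogen on a nitrogen on an aromatic ring. The closest measured change, butyl in place of the same hydrogen, is a step that the two limits leave unreadable from compound 1 to compound 2. Phenyl in place of propyl on a saturated chain carbon is a step that the two limits leave unreadable from compound 2 to compound 3. Neither size can be read, so no definite size or direction can be expected in this assay from these changes. The expected step is a step that the limit leaves unreadable from compound 1 to compound 4. Compound 4 is estimated at 30 mg/kg, with an expected range of 10 mg/kg to 60 mg/kg. A result given only as a limit remains the likeliest outcome for compound 4.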

Compound 4, dose for half-maximal effect: > 20 mg/kg
Compound 4 ended at the assay's limit; the forecaster's own chance of this, stated with the estimate: 75%; the middle value lies beyond the limit too.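

No new step can be read: the steps joining compound 4 to compound 1, compound 2 and compound 3 all end in limits in this assay, and the series stands at: the limit of > 20 mg/kg in this assay, at which 4 of the 4 values shown sit.

The compounds shown leave open whether replacing the hydrogen on this nitrogen changes the read-out at all.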